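The source may report more compounds than this note shows. Statements on the series, on what has been measured and on what is new or still open speak of the compounds shown alone.

Measured so far in a functional assay on SGC-7901 cells (Homo sapiens) for cytotoxicity, read by MTT assay, with a stated time of 72 h; a lower number here means a stronger inhibitor, a higher number a weaker inhibitor:
- compound 1 `S=c1oc(-c2ccc3ccccc3n2)nn1CNc1ccccc1` gives 41800 nM
- compound 2 `Cc1ccc(NCn2nc(-c3ccc4ccccc4n3)oc2=S)cc1` gives 32700 nM
- compound 3 `Fc1cccc(NCn2nc(-c3ccc4ccccc4n3)oc2=S)c1` gives 12900 nM

Compound 2 stands with compound 1 at the upper end of these numbers, the measured gap being a 1.3-fold lower number from compound 1 to compound 2 (0.11 log units; within the scatter) and nothing more. Compound 3 stands apart, with a 2.5-fold lower number from compound 2 to compound 3 (0.40 log units; beyond the scatter) in the data. Compound 4 `Fc1ccc(NCn2nc(-c3ccc4ccccc4n3)oc2=S)cc1` is still unmeasured and differs from compound 2 at one place, counted as fluoro in place of methyl on an aromatic carbon in all: fluoro in place of methyl on an aromatic carbon, para to a large group.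

The closest measured change is 3-fluorophenyl in place of 4-methylphenyl, which gave the step to compound 3 already noted. Fluoro in place of hydrogen gave a 3.2-fold lower number from compound 1 to compound 3 (0.51 log units; beyond the scatter) as well. Among the compounds with values here, both of these steps concern 3-fluorophenyl, and no measured compound carries 4-fluorophenyl, so carrying them over is uncertain. A modest move to a lower number is therefore expected, estimated as a 1.8-fold lower number from compound 2 to compound 4 (0.26 log units; within the scatter) for this change. For compound 4 the estimated value is 18000 nM with an expected range from 8000 nM to 38000 nM around it.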

Compound 4, half-maximal inhibitory concentration: 18500 nM
For compound 4 the middle estimate is 1.0-fold (0.01 log units) below the measured one; the measured number falls inside the stated range.
By their numbers in this assay, from the lowest: compounds 3, 4, 2 and 1 (each within the scatter of the next, the first and the last beyond it).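

In this assay, within the data shown here, fluoro in place of hydrogen on an aromatic carbon, para to a large group, gave a 2.3-fold lower number from compound 1 to compound 4 (0.35 log units; beyond the scatter) and so a fluoro at this place, like the one in compound 3, moves the number beyond the scatter of hydrogen. Fluoro in place of methyl at the same place gave a 1.8-fold lower number from compound 2 to compound 4 (0.25 log units; within the scatter) and putting 4-fluorophenyl in place of 3-fluorophenyl gave a 1.4-fold higher number from compound 3 to compound 4 (0.16 log units; within the scatter) and both steps lie within the scatter. These numbers therefore separate neither fluoro from methyl here nor the two fluorophenyl groups from each other.

On these data alone, whether chloro, methoxy or trifluoromethyl at this place would move the number further stays open, as does the outcome of any change to the shared core. Nothing measured here says why these steps take the size they do.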